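Removing the Ring-Nitrogen Methyl: What to Expect for Compound 4

This account rests on a few compounds, and the source may have more. Where it says the series, first, only, none or still open, it means among the compounds named here.

Three analogues sharing one core have been measured in a functional assay on CCRF-CEM cells for antagonist activity at C-X-C chemokine receptor type 4 (Homo sapiens), read by calcium flux, with stated times of 25 min and 90 s; a higher number here means a weaker inhibitor, a lower number a stronger inhibitor. Compound 1 `CN(C[C@H]1Cc2c(cccc2N2CCN(C3CC3)CC2)CN1)[C@H]1CCCc2cccnc21` gives 23.5 nM, compound 2 `CN(C[C@H]1Cc2c(cccc2N2CCN(Cc3ccccn3)CC2)CN1)[C@H]1CCCc2cccnc21` gives 4.47 nM, and compound 3 `CN1CCN(c2cccc3c2C[C@H](CN(C)[C@H]2CCCc4cccnc42)NC3)CC1` gives 29.6 nM, the highest of the three numbers, although its gap to compound 1 lies within the scatter. Compound 4 `CN(C[C@H]1Cc2c(cccc2N2CCNCC2)CN1)[C@H]1CCCc2cccnc21` differs from compound 3 by hydrogen in place of methyl on an amine nitrogen in a ring. Among the measured compounds shown here, the nearest precedent is the exchange of small groups on that same ring nitrogen: a 1.3-fold higher number from compound 1 to compound 3 (0.10 log units; within the scatter). Larger steps appeared only with the larger group of compound 2, since a 5.3-fold lower number from compound 1 to compound 2 (0.72 log units; beyond the scatter) and a 6.6-fold higher number from compound 2 to compound 3 (0.82 log units; beyond the scatter). Swapping methyl for hydrogen is therefore expected to give at most a small step, a 1.3-fold higher number from compound 3 to compound 4 (0.11 log units; within the scatter). Compound 4 is accordingly estimated at 38 nM, within a range of 12 nM to 120 nM.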

Compound 4, half-maximal inhibitory concentration: 6.08 nM
Beside the measured number, compound 4's estimate is 6.3-fold (0.80 log units) above it; the measured number lies below the stated range.
By their numbers in this assay, from the lowest: compounds 2 and 4 (each within the scatter of the next); then compounds 1 and 3 (each within the scatter of the next).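

In this assay, the change from 4-methylpiperazin-1-yl to piperazin-1-yl is a real step, a 4.9-fold lower number from compound 3 to compound 4 (0.69 log units; beyond the scatter), and replacing cyclopropyl with hydrogen gives a 3.9-fold lower number from compound 1 to compound 4 (0.59 log units; beyond the scatter), so this ring nitrogen responds to small groups in a way that the comparison of compound 1 and compound 3 did not show. A large group is also not required for a low number here, as hydrogen and (pyridin-2-yl)methyl sit close together, a 1.4-fold higher number from compound 2 to compound 4 (0.13 log units; within the scatter). No measurement shown explains these differences. On these data alone, it remains open whether an ethyl group, an acetyl group or a longer chain ending in a carboxylic acid on this nitrogen would track hydrogen or methyl.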